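This account rests on a few compounds, and the source may have more. Where it says the series, first, only, none or still open, it means among the compounds named here.

Of the compounds shown here, two have been measured in a functional assay on cells for antagonist activity at C-C chemokine receptor type 4 (Homo sapiens), read by fluorescence and calcium flux, with stated times of 2.5 s and 45 s; a higher number here means a weaker inhibitor, a lower number a stronger inhibitor. Compound 1 `Cc1nn([C@H](C)c2ccc(Cl)cc2Cl)c2nc(N3CC[C@H](N4CCC[C@H]4C(N)=O)[C@H](C)C3)cnc12` gives 170 nM, whereas compound 2 `CC(c1ccc(Cl)cc1Cl)n1ncc2ncc(N3CCC(N4CCCCC4)CC3)nc21` gives 2580 nM, the highest number of the two; the gap between compound 1 and compound 2 lies well beyond the scatter of repeated measurements. Compound 3 `CC1CN(c2cnc3cnn(C(C)c4ccc(Cl)cc4Cl)c3n2)CCC1N1CCCCC1` has not yet been measured. It differs from compound 2 in one place: methyl in place of hydrogen on a saturated ring carbon. Going by the values given here, no directly comparable pair has been measured, but compound 1, which also carries a methyl on its saturated six-membered ring, gives 170 nM, while differing from compound 3 in several other places as well. Compound 3 is therefore expected to show a moderate step toward a lower number, estimated as a 3.2-fold lower number from compound 2 to compound 3 (0.51 log units; beyond the scatter). Compound 3 is expected to give about 800 nM, within a range from 250 nM to 2600 nM.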

Compound 3, half-maximal inhibitory concentration: 238 nM
Compound 3: the middle estimate sits 3.4-fold (0.53 log units) above what was measured, and the stated range ends above it.
By their numbers in this assay, from the lowest: compounds 1 and 3 (each within the scatter of the next); then compound 2.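

In this assay, going by these compounds alone, a single methyl on a saturated ring carbon, next to the ring atom that bears a piperidin-1-yl group, gives an 11-fold lower number from compound 2 to compound 3 (1.04 log units; beyond the scatter) as the only change in the structure. This shows that one added carbon at this position can by itself shift the value by a large amount, which could not be read from compound 1 and compound 2, as they differ in several places at once. Nothing available explains why this small change has so large an effect.

From the compounds shown here alone, it remains open whether an ethyl group, a hydroxyl group or a fluorine atom on the same ring carbon would give a similar step. Going by these compounds, compound 3 is also drawn without a defined spatial arrangement at its methyl-bearing carbon, so the contribution of each arrangement remains unknown.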